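Fluoro to Methoxy on the Aryl at the Saturated Carbon

The source may hold more compounds than are shown below. What is called first, only, known or untested is meant among the compounds shown, and "the series" means these compounds.

Going by the values given here, compound 2 `COc1ccc(C2=NN(c3ccc(-c4ccccc4)nn3)C(c3ccc(F)cc3)C2)cc1` gives the only number in a functional assay on Caco-2 cells (Homo sapiens) for antiproliferative activity, read by MTT assay, with a stated time of 24 h (a higher number here means a weaker inhibitor, a lower number a stronger inhibitor), namely 18100 nM. Compound 1 `COc1ccc(C2CC(c3ccccc3)=NN2c2ccc(-c3ccccc3)nn2)cc1` reports > 100000 nM, which is a limit of the assay; this is the limit of > 100000 nM in this assay, at which 1 of the 2 values shown sits. Compound 3 `COc1ccc(C2=NN(c3ccc(-c4ccccc4)nn3)C(c3ccc(OC)cc3)C2)cc1` has not yet been measured and differs from compound 2 by methoxy in place of fluoro on an aromatic carbon. Among the compounds with values here, no measured pair shows this change, so only a modest step is expected, if any toward weaker inhibition, as a 1.4-fold higher number from compound 2 to compound 3 (0.14 log units; within the scatter). In this assay compound 3 is therefore estimated at 25000 nM, within 8000 nM to 80000 nM.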

Compound 3, half-maximal inhibitory concentration: > 100000 nM
Compound 3: only a limit was reported (the forecaster's own chance of this, stated with the estimate: 25%); at least 4.0-fold (0.60 log units) between middle value and limit.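

In this assay, going by these compounds alone, methoxy in place of fluoro on an aromatic carbon gives an at least 5.5-fold higher number from compound 2 to compound 3 (0.74 log units; beyond the scatter), the first readable step at this position, and it shows that the position does not tolerate every group equally. As far as these compounds go, compound 3 gives a limit of the assay, not a number, so the full size of this step stays unknown: the limit of > 100000 nM in this assay, at which 2 of the 3 values shown sit. The step between compound 1 and compound 3 cannot be read, since both values are limits.

The compounds shown leave open whether a chloro, a hydroxyl or an amine here would keep a measurable number.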